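Adding (4-methylphenyl)sulfonyl to compound 3

The source may hold more compounds than are shown below. What is called first, only, known or untested is meant among the compounds shown, and "the series" means these compounds.

Measured so far in a functional assay on NCI-H460 cells (Homo sapiens) for cytotoxicity, read by MTT assay, with a stated time of 3 days; a lower number here means a stronger inhibitor, a higher number a weaker inhibitor:

Compound 1 `N#Cc1c(Nc2nccs2)nc(SCc2nc3ccccc3[nH]2)nc1-c1ccccc1`: 3.37 nM
Compound 2 `N#Cc1c(NNC(N)=S)nc(SCc2nc3ccccc3[nH]2)nc1-c1ccccc1`: 3.37 nM
Compound 3 `N#Cc1c(-c2ccccc2)nc(SCc2nc3ccccc3[nH]2)nc1N1CCNCC1`: 7.35 nM

Compound 3 carries the highest number of the three, at 7.35 nM in this assay, though the whole set spans a narrow range. Compound 4 `Cc1ccc(S(=O)(=O)N2CCN(c3nc(SCc4nc5ccccc5[nH]4)nc(-c4ccccc4)c3C#N)CC2)cc1` departs from compound 3 at the amine nitrogen in a ring: (4-methylphenyl)sulfonyl in place of hydrogen on an amine nitrogen in a ring. In short, (4-methylphenyl)sulfonyl stands in place of hydrogen.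

For the measured compounds named here, no measured step makes this change. The nearest evidence comes from changes elsewhere on the shared core, and it is only indirect. Both a 2.2-fold higher number from compound 1 to compound 3 (0.34 log units; beyond the scatter) and a 2.2-fold higher number from compound 2 to compound 3 (0.34 log units; beyond the scatter) are modest, while no change at the digits printed from compound 1 to compound 2 (within the scatter) stays within the scatter. These steps show that the numbers moved little across the groups tried so far, but none of them tests a group added to this nitrogen. Going by these compounds, the direction of any change therefore remains open, and the range must stay wide on both sides. The expected step is a 1.2-fold lower number from compound 3 to compound 4 (0.09 log units; within the scatter), which would not lie beyond the scatter. In this assay compound 4 is estimated at 6 nM, with an expected range of 2.5 nM to 18 nM.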

Compound 4, half-maximal inhibitory concentration: 22.7 nM
Beside the measured number, compound 4's estimate is 3.8-fold (0.58 log units) below it, outside the stated range (above it).
By their numbers in this assay, from the lowest: compounds 1 and 2 (each within the scatter of the next); then compound 3; then compound 4.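

In this assay, for the compounds shown here, the earlier compounds kept a hydrogen on the amine nitrogen in the ring of compound 3, so this change gives the first reading of a group placed there, and that reading is a 3.1-fold higher number from compound 3 to compound 4 (0.49 log units; beyond the scatter). The step runs toward a weaker inhibitor and lies beyond the scatter, which shows that this nitrogen is not indifferent to what it carries, although the step is only modest and compound 4 still reads 22.7 nM with a group of 10 heavy atoms in place of hydrogen. No measurement shown here accounts for the size or direction of this step.

With a single substituent on this nitrogen, the compounds shown cannot tell whether the step goes with the sulfonyl link itself or with the 4-methylphenyl ring it carries. A methyl, an acetyl or a methanesulfonyl group on the same nitrogen, or a 4-methoxyphenylsulfonyl group in place of the 4-methylphenylsulfonyl, would begin to separate those two parts and show whether the number follows the size of the group or its kind.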